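The compounds below may be only part of what the source reports. "The series", "measured", "known", "first", "only" and "open" are said of these compounds alone.

Working notes on the series. In an ADME assay on Vero cells (Chlorocebus sabaeus) for cytotoxicity, read by resazurin assay, with a stated time of 3 days (a higher number here means a weaker inhibitor, a lower number a stronger inhibitor), compound 1 `CCCCNC(=O)Nc1cc2nc(C3CCCCC3)[nH]c2cc1N(CC)CC` gives only a limit of the assay, > 100 ug/mL. Compound 2 `CCN(CC)c1cc2[nH]c(C3CCCCC3)nc2cc1NC(=O)c1ccc(C)cc1` likewise gives a limit, > 100 ug/mL. Compound 3 `CCCCNC(=O)Nc1cc2nc(C3CCCCC3)[nH]c2cc1N(C)C` also gives a limit, > 100 ug/mL. The change from compound 1 to compound 2 is 4-methylphenyl in place of butylamino on a carbonyl carbon; the step that the two limits leave unreadable from compound 1 to compound 2 cannot be sized because of the limit of > 100 ug/mL in this assay, at which 3 of the 3 values shown sit. The cores of compound 1 and compound 3 differ by dimethylamino in place of diethylamino on an aromatic carbon, and the step that the two limits leave unreadable from compound 1 to compound 3 is likewise unreadable.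

Compound 4 `Cc1ccc(C(=O)Nc2cc3nc(C4CCCCC4)[nH]c3cc2N(C)C)cc1`, not yet measured, carries the same change on the core of compound 3: 4-methylphenyl in place of butylamino on a carbonyl carbon. Since compound 1 and compound 2 both sit at the limit, the step that the limit leaves unreadable from compound 3 to compound 4 is expected to be flat. Compound 4 is therefore estimated at 120 ug/mL in this assay, most likely again reported as a limit.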

Compound 4, half-maximal inhibitory concentration: > 100 ug/mL
Compound 4: no number, only a limit; the forecaster's own chance of this, stated with the estimate: 85%; the middle value lies beyond the limit too.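

No step can be read from compound 3 or compound 2 to compound 4, which again gives only a limit: the limit of > 100 ug/mL in this assay, at which 4 of the 4 values shown sit.

The compounds shown leave open whether 4-methylphenyl in place of butylamino, or dimethylamino in place of diethylamino, changes the read-out at all.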